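The source may hold more compounds than are shown below. What is called first, only, known or untested is meant among the compounds shown, and "the series" means these compounds.

Compound 3, with structure `N#C/C(=C\C=C(/Cl)c1ccc(Br)cc1)C(=O)c1c[nH]c2ccc(Br)cc12`, is one of three members of this series tested in a functional assay on MCF7 cells (Homo sapiens) for cytotoxicity, read by sulforhodamine B assay, with a stated time of 48 h (a higher number here means a weaker inhibitor of growth, a lower number a stronger inhibitor of growth), a panel in which compound 1, `COc1ccc(/C(Cl)=C/C=C(\C#N)C(=O)c2c[nH]c3ccccc23)cc1`, gives 47300 nM and compound 2, `COc1cc(/C(Cl)=C/C=C(\C#N)C(=O)c2c[nH]c3ccc(Br)cc23)cc(OC)c1OC`, gives 30800 nM. For compound 3 the assay reports only a limit, > 100000 nM. That places compound 3 at the limit of > 100000 nM in this assay, at which 1 of the 3 values shown sits, so its true value is not known, only that it lies beyond what the assay could read.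

Compound 4, `COc1ccc(/C(Cl)=C/C=C(\C#N)C(=O)c2c[nH]c3ccc(Br)cc23)cc1`, differs from compound 3 in a single respect: methoxy in place of bromo on an aromatic carbon. Going by the values given here, none of the measured compounds differ from one another in just one place, so the size of this kind of change cannot be read from any measured pair. What the measured compounds do show is that the same methoxy group on the phenyl ring that compound 4 carries is present in compound 1, which sits at 47300 nM, and that the bromo-substituted core that compound 4 carries is shared by compound 2, which sits at 30800 nM. On that basis the step from compound 3 to compound 4 is expected to bring a number back within the range of the assay, an at least 2.5-fold lower number from compound 3 to compound 4 (0.39 log units; beyond the scatter). Compound 4 is therefore expected to show 40000 nM in this assay, with a likely span from 15000 nM to 100000 nM.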

Compound 4, concentration for 50% growth inhibition: 80300 nM
Compound 4: middle estimate off by 2.0-fold (0.30 log units), on the low side, within the range that was stated.
By their numbers in this assay, from the lowest: compounds 2, 1 and 4 (each within the scatter of the next, the first and the last beyond it). At a limit, above all of these: compound 3.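

Going by these compounds alone, with compound 4 in hand, the change from 4-bromophenyl to 4-methoxyphenyl, para to a large group, can for the first time be read on a pair of compounds, and it gives an at least 1.2-fold lower number from compound 3 to compound 4 (0.09 log units; that floor lies within the scatter). Within the data shown here, compound 3 remains a limit and not a number in this assay, so this pair fixes only a floor for the step, and that floor does not by itself separate methoxy from bromo at this position: the limit of > 100000 nM in this assay, at which 1 of the 4 values shown sits. Compound 4 also supplies the first pair for a change on the shared core, with a 1.7-fold higher number from compound 1 to compound 4 (0.23 log units; within the scatter), so bromo in place of hydrogen there gives no reading that stands apart from the usual scatter of this assay.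

On these data alone, the true size of the step at the phenyl position stays open, as does whether it lies beyond the scatter at all, for as long as compound 3 has only a limit. Also open, as far as these compounds go, is how an amine, a carboxylic acid or a longer alkoxy chain at this same position would read, and whether any of these would stand apart from methoxy and bromo.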